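The source may report more compounds than this note shows. Statements on the series, on what has been measured and on what is new or still open speak of the compounds shown alone.

Compound 3 `COc1cc2ncnc(Nc3ccc(F)c(Br)c3)c2cc1OCCCCC(=O)Nc1ccc(S(N)(=O)=O)cc1` carries a 3-bromo-4-fluorophenyl group on a nitrogen on an aromatic ring; in a functional assay on A549 cells (Homo sapiens) for antiproliferative activity, read by MTT assay, with a stated time of 72 h (on this read-out higher numbers stand for weaker inhibition and lower numbers for stronger inhibition), compound 3 gives 16000 nM. Among the numbers measured this is the highest of the two: compound 1 `C#Cc1cccc(Nc2ncnc3cc(OC)c(OCCCCC(=O)Nc4ccc(S(N)(=O)=O)cc4)cc23)c1` gives 7720 nM, and the step is a 2.1-fold higher number from compound 1 to compound 3 (0.32 log units; beyond the scatter). Compound 2 `COc1ccc(Nc2ncnc3cc(OC)c(OCCCCC(=O)Nc4ccc(S(N)(=O)=O)cc4)cc23)cc1OC` sits at the limit of > 40000 nM in this assay, at which 1 of the 3 values shown sits, and its value of > 40000 nM is a limit of the assay, not a number. From that limit the step is an at least 2.5-fold lower number from compound 2 to compound 3 (0.39 log units; beyond the scatter), while an at least 5.1-fold higher number from compound 1 to compound 2 (0.71 log units; beyond the scatter) runs the other way. Compound 4 `COc1cc2ncnc(Nc3ccc(C(F)(F)F)cc3)c2cc1OCCCCC(=O)Nc1ccc(S(N)(=O)=O)cc1` has not yet been measured; it differs from compound 3 in that (4-(trifluoromethyl)phenyl in place of 3-bromo-4-fluorophenyl on a nitrogen on an aromatic ring). Among the measured compounds shown here, no measured step makes exactly this change, but the three steps at the group on a nitrogen on an aromatic ring, all beyond the scatter, show that this group moves the number by at least a modest amount. A step of a 1.6-fold higher number from compound 3 to compound 4 (0.19 log units; within the scatter) toward a somewhat higher number is expected. Compound 4 is therefore estimated at 25000 nM, with a range from 8000 nM to 80000 nM.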

Compound 4, half-maximal inhibitory concentration: 14800 nM
The estimate for compound 4 lay 1.7-fold (0.23 log units) above the measured number; low and high end bracket the measured number.
By their numbers in this assay, from the lowest: compounds 1, 4 and 3 (each within the scatter of the next, the first and the last beyond it). At a limit, above all of these: compound 2.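

In this assay, the swap of 3-bromo-4-fluorophenyl for 4-(trifluoromethyl)phenyl on the nitrogen gives no readable difference, with a 1.1-fold lower number from compound 3 to compound 4 (0.03 log units; within the scatter), so this position can hold a group without bromine and the number stays within the scatter of compound 3. The step of a 1.9-fold higher number from compound 1 to compound 4 (0.28 log units; within the scatter) also stays within the scatter, so compound 4 cannot be separated from compound 1 either, although compounds 1 and 3 themselves lie beyond it. The step of an at least 2.7-fold lower number from compound 2 to compound 4 (0.43 log units; beyond the scatter) sets compound 4 apart from compound 2, whose value is a limit and not a number: the limit of > 40000 nM in this assay, at which 1 of the 4 values shown sits.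

The compounds shown leave open whether an amine or a carboxylic acid on the group at this nitrogen would change the number. They also leave open whether a longer chain in the part shared by all four compounds would do so.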